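From Cyanophenyl Back to Butyl on a Shared Core

A few compounds are considered here, and "the series" means these few. Any claim that something is new, unique, unknown or untested is made for them only; others in the source may bear on it.

Among the compounds with values here, compound 3 `CN1CCc2ccc(NS(=O)(=O)c3ccc(-c4ccc(C#N)cc4)cc3)cc2CC1` gives 25.1 nM in an assay on isolated protein for displacement of a labelled ligand from 5-hydroxytryptamine receptor 6 (Homo sapiens), read by radioligand binding (on this read-out lower numbers stand for stronger inhibition and higher numbers for weaker inhibition), the highest of the three numbers measured so far; compound 2 `CN1CCc2ccc(NS(=O)(=O)c3ccc(-c4ccc(F)c(Cl)c4)cc3)cc2CC1` gives 7.94 nM and compound 1 `CCCCc1ccc(S(=O)(=O)Nc2ccc3c(c2)CCNCC3)cc1` gives 2 nM. Compound 4 `CCCCc1ccc(S(=O)(=O)Nc2ccc3c(c2)CCN(C)CC3)cc1` has not yet been measured. It differs from compound 3 by butyl in place of 4-cyanophenyl on an aromatic carbon. Within the data shown here, the only measured step at this position, a 3.2-fold higher number from compound 2 to compound 3 (0.50 log units; beyond the scatter), shows that changing the group on this aromatic carbon shifts the number modestly. Compound 1 carries the same butyl group as compound 4 and shows the lowest number of the set. Compound 4 is therefore expected to give a lower number, a step of about an 8.4-fold lower number from compound 3 to compound 4 (0.92 log units; beyond the scatter), with an estimate of 3 nM and a likely range from 1 nM to 10 nM.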

Compound 4, inhibition constant: 1.26 nM
The estimate for compound 4 lay 2.4-fold (0.38 log units) above the measured number; low and high end bracket the measured number.
By their numbers in this assay, from the lowest: compounds 4 and 1 (each within the scatter of the next); then compound 2; then compound 3.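

Butyl on this aromatic carbon gives a lower number than either substituted phenyl group (a 20-fold lower number from compound 3 to compound 4 (1.30 log units; beyond the scatter); a 6.3-fold lower number from compound 2 to compound 4 (0.80 log units; beyond the scatter)), and the step from 4-cyanophenyl is larger than the one between the two phenyl groups (a 3.2-fold higher number from compound 2 to compound 3 (0.50 log units; beyond the scatter)). So replacing the whole phenyl group with a butyl chain counts for more here than changing what the phenyl group carries. With butyl in place, methyl on the ring nitrogen cannot be told apart from hydrogen (a 1.6-fold lower number from compound 1 to compound 4 (0.20 log units; within the scatter)).

As far as these compounds go, whether a propyl or a hexyl chain would serve as well as butyl remains open. Nothing measured here gives a cause for these steps.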